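This account rests on a few compounds, and the source may have more. Where it says the series, first, only, none or still open, it means among the compounds named here.

Measured compounds in an assay on isolated protein for displacement of a labelled ligand from metabotropic glutamate receptor 5 (Homo sapiens), with a stated time of 60 min, tested at 1 uM; a higher number here means more inhibition at the concentration tested (going by the name of the read-out), a lower number less inhibition:
- compound 1, `O=S(=O)(c1cccc(F)c1)c1cnc2cc(Cl)ccc2c1N1CCC(CO)CC1`, gives 71%
- compound 2, `CC1CCN(c2c(S(=O)(=O)c3ccc(F)cc3)cnc3cc(Cl)ccc23)CC1`, gives 91%
- compound 3, `COc1ccc(S(=O)(=O)c2cnc3ccc(C)cc3c2N2CCC(C)CC2)cc1`, gives 62%

Compound 2 stands highest of the three numbers. Compound 1 is nearest to it, and its value lies lower by more than the scatter; compound 3 is furthest, lower by a wider margin that is also beyond the scatter. For the measured compounds named here, no pair among the measured compounds differs in one place only, so no single step is isolated here, and the spread between compound 1, compound 2 and compound 3 mixes changes at more than one place of the shared core.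

Compound 4, `Cc1ccc(S(=O)(=O)c2cnc3cc(Cl)ccc3c2N2CCC(C)CC2)cc1F`, is not yet measured. It differs from compound 2 as follows: 3-fluoro-4-methylphenyl in place of 4-fluorophenyl on a sulfonyl sulfur.

Nothing in the measured set shows how this change alone acts, so the expectation rests on compound 2 being the highest value and on the read-out being close to its ceiling. The step is expected to be small and, if anything, downward, with a number 8 percentage points lower from compound 2 to compound 4 (within the scatter) not necessarily beyond the scatter. Compound 4 is expected to give 83%, within a range from 62% to 95%.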

Compound 4, a percentage reported as inhibition, at one concentration (the size of the read-out at that concentration, not a potency): 85%
The estimate for compound 4 lay 2 percentage points below the measured number; low and high end bracket the measured number.
By their numbers in this assay, from the lowest: compounds 3 and 1 (each within the scatter of the next); then compounds 4 and 2 (each within the scatter of the next).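

For the compounds shown here, on a sulfonyl sulfur, 3-fluoro-4-methylphenyl in place of 4-fluorophenyl gives the first step that isolates one place in this assay: a number 6 percentage points lower from compound 2 to compound 4 (within the scatter). The number therefore stays level across this one swap, without a difference that can be told from the scatter, with compound 2 at 91% and compound 4 at 85%, though a read-out at one concentration gives no potency for either. Nothing measured here explains the size of this step.

Still open, going by these compounds, is whether an amine or a carboxylic acid on this aromatic ring would move the number beyond the scatter. The compounds shown also leave open whether this step would stay the same with a different group elsewhere on the shared core, as the differences among compound 1, compound 2 and compound 3 cannot be read one place at a time.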